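Swapping a dimethyl amide for an isopropyl amide

The compounds below may be only part of what the source reports. "The series", "measured", "known", "first", "only" and "open" are said of these compounds alone.

Compound 1 `COc1cc2c(cc1OC)C(CC(N)=O)CC2`: 30.4%
Compound 2 `COc1cc2c(cc1OC)C(CC(=O)N(C)C)CC2`: 34.8%
Compound 3 `CCCNC(=O)CC1CCc2cc(OC)c(OC)cc21`: 29%

Three amides sharing one core were tested in a functional assay on the whole organism (strain Wistar) for inhibition, with Rattus norvegicus as the target, read by paw edema, with stated times of 60 min and 3 h, at a dose of 100 mg/kg by the oral route; on this read-out higher numbers stand for more inhibition at the one dose given (going by the name of the read-out) and lower numbers for less inhibition. Compound 2 sits highest of the three numbers, yet its margin over compound 1 is a number 4.4 percentage points higher from compound 1 to compound 2 (within the scatter) and its margin over compound 3 is a number 5.8 percentage points lower from compound 2 to compound 3 (within the scatter), both within the scatter, so no order among the three can be claimed. The step from compound 1 to compound 3 is likewise a number 1.4 percentage points lower from compound 1 to compound 3 (within the scatter).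

Compound 4 `COc1cc2c(cc1OC)C(CC(=O)NC(C)C)CC2` has not yet been measured. It differs from compound 2 by isopropylamino in place of dimethylamino on a carbonyl carbon. The closest guide is the step from compound 2 to compound 3, which also replaces dimethylamino with a secondary amide nitrogen and moves only within the scatter; the step from compound 1 to compound 2 is equally small. Compound 4 is therefore expected to show no step beyond the scatter, an estimated a number 3.8 percentage points lower from compound 2 to compound 4 (within the scatter). Compound 4 is expected to give about 31%, in the range 21% to 41%.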

Compound 4, a percentage reported as inhibition, in the whole organism at one dose (the size of the read-out at that dose, not a potency): 30.4%
Compound 4: the middle estimate sits 0.6 percentage points above what was measured; the range from low to high includes it.
By their numbers in this assay, from the lowest: compounds 3, 1, 4 and 2 (each within the scatter of the next).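

Among the compounds shown here, at this carbonyl carbon, isopropylamino in place of dimethylamino gives a number 4.4 percentage points lower from compound 2 to compound 4 (within the scatter) in this assay and so adds a second secondary amide to the one case that compound 3 had offered, again without a step beyond the scatter. On the amide-type nitrogen, isopropyl in place of propyl gives a number 1.4 percentage points higher from compound 3 to compound 4 (within the scatter) and isopropyl in place of hydrogen gives no change at the digits printed from compound 1 to compound 4 (within the scatter) so neither the shape of this small chain nor its presence separates these compounds at this single dose. Nothing given here accounts for these numbers.

Going by these compounds, whether a much longer chain such as octyl, a benzyl group or a piperidine amide would move the number beyond the scatter stays open. So does the effect of a carboxylic acid in place of the amide.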